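Compound 3 and the loss of one methoxy

The source may report more compounds than this note shows. Statements on the series, on what has been measured and on what is new or still open speak of the compounds shown alone.

Measured in a functional assay on HT-1080 cells (Homo sapiens) for antiproliferative activity, read by sulforhodamine B assay, with a stated time of 48 h; a higher number here means a weaker inhibitor, a lower number a stronger inhibitor:
compound 1 `Cc1cc(C)cc(NS(=O)(=O)c2ccc(N3CCNC3=O)cc2)c1`: 150 nM
compound 2 `Cc1ccc(C)c(NS(=O)(=O)c2ccc(N3CCNC3=O)cc2)c1`: 65 nM
compound 3 `COc1cc(NS(=O)(=O)c2ccc(N3CCNC3=O)cc2)cc(OC)c1`: 150 nM

Compound 3 stands level with compound 1, and both numbers lie above that of compound 2. Compound 4 `COc1cccc(NS(=O)(=O)c2ccc(N3CCNC3=O)cc2)c1` has hydrogen in place of methoxy on an aromatic carbon of compound 3 (hydrogen in place of methoxy on an aromatic carbon). Going by the values given here, only one measured step is available, a 2.3-fold lower number from compound 1 to compound 2 (0.36 log units; beyond the scatter). It exchanges 3,5-dimethylphenyl for 2,5-dimethylphenyl and removes no group, so it suggests a likely size but no direction. A small move to a higher number in this assay is expected, perhaps no larger than the scatter. The estimated change is a 1.5-fold higher number from compound 3 to compound 4 (0.19 log units; within the scatter). For compound 4 the expected value is 230 nM, with an estimated range of 90 nM to 600 nM.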

Compound 4, half-maximal inhibitory concentration: 200 nM
Beside the measured number, compound 4's estimate is 1.2-fold (0.06 log units) above it; measured number inside the range.
By their numbers in this assay, from the lowest: compound 2; then compounds 1, 3 and 4 (each within the scatter of the next).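

In this assay the loss of one methoxy gives a 1.3-fold higher number from compound 3 to compound 4 (0.12 log units; within the scatter) and so hydrogen and methoxy cannot be told apart at this aromatic carbon. The same holds for a 1.3-fold higher number from compound 1 to compound 4 (0.12 log units; within the scatter) while a 3.1-fold higher number from compound 2 to compound 4 (0.49 log units; beyond the scatter) sets compound 2 beyond the scatter from compound 4. Nothing measured here explains these numbers.

Going by these compounds, whether an amine or a carboxylic acid on this carbon would read like hydrogen and methoxy stays open. So does the part played by the methoxy that remains in compound 4.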